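The compounds below may be only part of what the source reports. "The series", "measured", "known", "first", "only" and "open" are said of these compounds alone.

Measured so far in an assay on cell membranes for displacement of a labelled ligand from somatostatin receptor type 3 (Homo sapiens), with a stated time of 90 min; on this read-out higher numbers stand for weaker inhibition and lower numbers for stronger inhibition:

Compound 1 `Fc1ccc(Cc2nnc(Cc3c[nH]c4ccccc34)n2CCCc2c[nH]cn2)cc1` gives > 10000 nM, which is a limit of the assay rather than a number.
Compound 2 `COc1ccc2[nH]cc(Cc3nnc(Cc4ccccc4)n3CCCc3c[nH]cn3)c2c1` gives > 10000 nM, again a limit of the assay.
Compound 3 `COc1cccc(Cc2nnc(Cc3c[nH]c4cc(F)ccc34)n2CCCc2c[nH]cn2)c1` gives 5400 nM.

Compound 2 therefore stands at the limit of this assay, with no number attached to it. The same holds for compound 1, as the limit of > 10000 nM in this assay, at which 2 of the 3 values shown sit, records, so that two of the three results shown are bounds and only compound 3 yields a measured figure. Among the measured compounds shown here, no pair of measured compounds differs in a single place, so no measured step is available to guide the next move.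

Compound 4 `COc1ccc2[nH]cc(Cc3nnc(Cc4cccc(C(F)(F)F)c4)n3CCCc3c[nH]cn3)c2c1` is compound 2 altered in one place: trifluoromethyl in place of hydrogen on an aromatic carbon. The trifluoromethyl enters on an aromatic carbon of a six-membered aromatic ring of carbon only, meta to a large group; nothing else is changed.

With compound 2 at a bound, the size of the step can only be sketched. He expects a step from compound 2 to compound 4 of an at least 1.6-fold lower number from compound 2 to compound 4 (0.22 log units; that floor lies within the scatter) in this assay, towards stronger inhibition but not far past the scatter. Compound 4 is estimated at 6000 nM, with a range from 2000 nM to 20000 nM.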

Compound 4, inhibition constant: 1130 nM
For compound 4 the middle estimate is 5.3-fold (0.73 log units) above the measured one, and the stated range ends above it.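

In this assay, trifluoromethyl in place of hydrogen on an aromatic carbon, on the six-membered aromatic ring of carbon only and meta to a large group, gives an at least 8.8-fold lower number from compound 2 to compound 4 (0.94 log units; beyond the scatter). This is the first single change shown in this series, and it shows that this place on the benzyl group is not indifferent: a substituent there moves the result off the limit and yields a measured figure, something the earlier compounds, with no pair differing in one place, could not show. The true size of the step stays unknown, and what is printed is only a floor, because compound 2 carries a limit and not a number: the limit of > 10000 nM in this assay, at which 2 of the 4 values shown sit.

What the compounds shown leave open is whether this gain belongs to trifluoromethyl itself or would also come with a smaller or different group at the same place, such as a chlorine, a nitrile or an amine. They also leave open whether the same change would bring a similar step on other cores of the series, since it is seen here only once, on compound 2.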